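Notes on the step from compound 3 to compound 4

The source may report more compounds than this note shows. Statements on the series, on what has been measured and on what is new or still open speak of the compounds shown alone.

Measured in a functional assay on A549 cells (Homo sapiens) for antiproliferative activity, read by MTT assay, with a stated time of 72 h; on this read-out higher numbers stand for weaker inhibition and lower numbers for stronger inhibition:
- compound 1 `CNc1nc(-c2cc(OC)c(OC)c(OC)c2)c(-c2ccc3ccccc3c2)s1`: 151 nM
- compound 2 `CNc1nc(-c2cc(OC)c(OC)c(OC)c2)c(-c2ccc(C)cc2)s1`: 125 nM
- compound 3 `COc1cc(-c2nc(N(C)C)sc2-c2ccc3ccccc3c2)cc(OC)c1OC`: 2900 nM

Among these three, compound 3 has the highest number. Compound 4 `COc1cc(-c2nc(N(C)C)sc2-c2ccc(C)cc2)cc(OC)c1OC`, not yet measured, carries 4-methylphenyl in place of naphthalen-2-yl on an aromatic carbon next to the ring sulfur (4-methylphenyl in place of naphthalen-2-yl on an aromatic carbon).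

Within the data shown here, the only measured step, a 19-fold higher number from compound 1 to compound 3 (1.28 log units; beyond the scatter), is methyl in place of hydrogen on a nitrogen, so it sets the level of compound 3 and does not test the present change. The closest evidence is a pair of values: compound 1 gives 151 nM and compound 2 gives 125 nM, within the scatter of each other. On that basis, no step beyond the scatter is expected in this assay. The data do not show whether this holds with the dimethylamino group, so the range is kept wide.

The expected step is a 1.2-fold lower number from compound 3 to compound 4 (0.08 log units; within the scatter). Compound 4 is estimated at 2400 nM, with an expected range of 700 nM to 7000 nM.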

Compound 4, half-maximal inhibitory concentration: 3960 nM
For compound 4 the middle estimate is 1.7-fold (0.22 log units) below the measured one, within the range that was stated.
By their numbers in this assay, from the lowest: compounds 2 and 1 (each within the scatter of the next); then compounds 3 and 4 (each within the scatter of the next).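

In this assay, 4-methylphenyl in place of naphthalen-2-yl on an aromatic carbon next to the ring sulfur gives a 1.4-fold higher number from compound 3 to compound 4 (0.14 log units; within the scatter), so with the dimethylamino group the two aryl groups cannot be told apart at this position. The other new step, methyl in place of hydrogen on the nitrogen, gives a 32-fold higher number from compound 2 to compound 4 (1.50 log units; beyond the scatter), which shows that the large step seen with naphthalen-2-yl also appears with 4-methylphenyl. The size of this step therefore shows no dependence on which of the two aryl groups is present: the same change on two cores in this assay, a 19-fold higher number (1.28 log units; beyond the scatter) from compound 1 to compound 3 and a 32-fold higher number (1.50 log units; beyond the scatter) from compound 2 to compound 4, 1.6-fold (0.22 log units) apart, within the scatter of two such steps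

Open, on these data alone, is how the unsubstituted amine or a longer chain such as ethyl on the nitrogen would compare with hydrogen and methyl. Also open is whether this aromatic carbon would accept 4-methoxyphenyl or 4-chlorophenyl as readily as the two aryl groups shown.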